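Aryl swap on the oxadiazole: a forecast for compound 3

The source may hold more compounds than are shown below. What is called first, only, known or untested is meant among the compounds shown, and "the series" means these compounds.

Measured compounds:
compound 1 `CCCc1noc(C2CCN(c3ncnc(Nc4ccc(S(C)(=O)=O)cc4)c3[N+](=O)[O-])CC2)n1` gives 430 nM in a functional assay for agonist activity at Glucose-dependent insulinotropic receptor (Homo sapiens); a lower number here means that less compound is needed, a higher number that more compound is needed for the effect
compound 2 `CS(=O)(=O)c1ccc(Nc2ncnc(N3CCC(c4nc(-c5cccnc5)no4)CC3)c2[N+](=O)[O-])cc1` gives 660 nM in this assay

Within the data shown here, compound 2 holds the higher of the two numbers measured so far, with compound 1 as its only neighbour; the gap between them is a 1.5-fold higher number from compound 1 to compound 2 (0.19 log units; within the scatter), so the two are not separated beyond the usual scatter. Compound 3 `CS(=O)(=O)c1ccc(Nc2ncnc(N3CCC(c4nc(-c5cccc(C(F)(F)F)c5)no4)CC3)c2[N+](=O)[O-])cc1` has not yet been measured. It differs from compound 2 in one place: 3-(trifluoromethyl)phenyl in place of pyridin-3-yl on an aromatic carbon.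

Among the measured compounds shown here, only one measured step touches the same aromatic carbon of the five-membered ring, the exchange of propyl for pyridin-3-yl, and that step was a 1.5-fold higher number from compound 1 to compound 2 (0.19 log units; within the scatter), small and inside the scatter. Nothing measured here speaks directly to a 3-(trifluoromethyl)phenyl at this place. For the measured compounds named here, since the one change already seen at this position left the number essentially unmoved, the step to compound 3 is expected to be small as well, in no firm direction, and the estimated step from compound 2 to compound 3 in this assay is a 1.3-fold lower number from compound 2 to compound 3 (0.12 log units; within the scatter). Compound 3 is therefore estimated at 500 nM, with a range from 200 nM to 1500 nM.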

Compound 3, half-maximal effective concentration: 24 nM
Compound 3: middle estimate off by 21-fold (1.32 log units), on the high side; the measured number lies below the stated range.
By their numbers in this assay, from the lowest: compound 3; then compounds 1 and 2 (each within the scatter of the next).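

In this assay, the exchange of pyridin-3-yl for 3-(trifluoromethyl)phenyl gave a 28-fold lower number from compound 2 to compound 3 (1.44 log units; beyond the scatter), and the exchange of propyl for the same group gave an 18-fold lower number from compound 1 to compound 3 (1.25 log units; beyond the scatter), so this aromatic carbon, between two ring nitrogen atoms, responds strongly to what it carries, which the earlier pair, lying within the scatter of each other, could not reveal. A six-membered aromatic ring at this place does not by itself bring the low number, as compound 2 carries one and stays within the scatter of compound 1, whereas compound 3 stands clearly apart from both. No independent measurement is at hand that would explain the size of this change.

As far as these compounds go, whether the gain belongs to the trifluoromethyl group or to the ring of carbon only remains open, since the two enter together in this single step, and a plain phenyl would be the group to separate them. Equally open, from the compounds shown here alone, is whether a chlorine atom or a methoxy group in place of the trifluoromethyl would hold the number down.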